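Changing the Phenyl Group on the Ring Amine Nitrogen

A few compounds are considered here, and "the series" means these few. Any claim that something is new, unique, unknown or untested is made for them only; others in the source may bear on it.

Measured so far:
compound 1, `Cc1nc(-c2ccccc2)c(C(=O)N2CCN(c3cccc(C(N)=O)c3)CC2)o1`, 71 nM
compound 2, `Cc1nc(-c2ccccc2)c(C(=O)N2CCN(c3ccccc3Cl)CC2)o1`, 124 nM
compound 3, `COc1cccc(N2CCN(C(=O)c3oc(C(F)(F)F)nc3-c3ccc(F)cc3)CC2)c1`, "not active" (no number reported)

Three compounds share a core and differ mainly in the group carried on an amine nitrogen in a ring. In a functional assay on HL-60 cells (Homo sapiens) for inhibition, read by MTT assay, with a stated time of 72 h (a lower number here means a stronger inhibitor, a higher number a weaker inhibitor), compound 1 gives 71 nM and compound 2 gives 124 nM; the step of a 1.7-fold higher number from compound 1 to compound 2 (0.24 log units; within the scatter) lies within the scatter, so the two cannot be ordered. Compound 3, which carries several further changes elsewhere, gives "not active" (no number reported), with no number reported. Among the two numbers available, compound 2 holds the higher one, and compound 1 is its only numerical neighbour.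

Compound 4, `Cc1nc(-c2ccccc2)c(C(=O)N2CCN(c3cccc(C(F)(F)F)c3)CC2)o1`, is not yet measured. It differs from compound 2 in one place: 3-(trifluoromethyl)phenyl in place of 2-chlorophenyl on an amine nitrogen in a ring. Among the compounds with values here, no measured step changes this group to a trifluoromethyl-bearing ring, so the only guide is that the one measured change at this place, from compound 1 to compound 2, stayed within the scatter, while compound 3, which carries a differently substituted phenyl here along with other changes, gave no number. On this basis no shift beyond the scatter is expected, and the step of a 1.2-fold higher number from compound 2 to compound 4 (0.08 log units; within the scatter) is the expectation. Compound 4 is therefore estimated at 150 nM in this assay, with a range from 60 nM to 400 nM.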

Compound 4, half-maximal inhibitory concentration: 153 nM
Compound 4: the middle estimate sits 1.0-fold (0.01 log units) below what was measured, within the range that was stated.
By their numbers in this assay, from the lowest: compounds 1, 2 and 4 (each within the scatter of the next, the first and the last beyond it).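

Replacing 2-chlorophenyl with 3-(trifluoromethyl)phenyl gives a 1.2-fold higher number from compound 2 to compound 4 (0.09 log units; within the scatter) in this assay, so these two substituted phenyl rings on the amine nitrogen cannot be told apart. Within the data shown here, the same compound also supplies the first step at this position that lies beyond the scatter, though only modestly: with trifluoromethyl in place of carbamoyl on an aromatic carbon, the result is a 2.2-fold higher number from compound 1 to compound 4 (0.33 log units; beyond the scatter). Compound 2 stays within the scatter of both neighbours, so the carbamoyl group in compound 1 can be separated only from the trifluoromethyl group in compound 4, not from every other ring tested here. No measurement shown here offers an explanation for these numbers.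

The compounds shown leave open how the number would move if the phenyl ring on this nitrogen carried an amine or a carboxylic acid, or if a longer chain took the place of the ring. Going by these compounds, it also remains open whether the missing number for compound 3 traces to the group at this place or to its changes elsewhere on the core.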